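From pyrazole to triazole on a shared core

The compounds below may be only part of what the source reports. "The series", "measured", "known", "first", "only" and "open" are said of these compounds alone.

Compounds 1, 2 and 3 share one core and differ only in the small aromatic ring attached to an aromatic carbon of a six-membered aromatic ring of carbon only. In a functional assay on a cell-free system (plasma) with sterol O-acyltransferase, Soat (Rattus norvegicus) as the target (a higher number here means that more compound is needed for the effect, a lower number that less compound is needed), compound 1 `Cc1cc(C)c(NC(=O)N(Cc2ccc(-c3ccsc3)cc2)C2CCCCCC2)c(C)c1` gives 0.51 mg/kg and compound 2 `Cc1cc(C)c(NC(=O)N(Cc2ccc(-c3cccnc3)cc2)C2CCCCCC2)c(C)c1` gives 0.58 mg/kg, and the step of a 1.1-fold higher number from compound 1 to compound 2 (0.06 log units; within the scatter). Compound 3 `Cc1cc(C)c(NC(=O)N(Cc2ccc(-c3cn[nH]c3)cc2)C2CCCCCC2)c(C)c1` gives > 1 mg/kg, which is a limit of the assay rather than a number. The steps of an at least 1.9-fold higher number from compound 1 to compound 3 (0.29 log units; that floor lies within the scatter) and an at least 1.7-fold higher number from compound 2 to compound 3 (0.23 log units; that floor lies within the scatter) both run into that limit (the limit of > 1 mg/kg in this assay, at which 1 of the 3 values shown sits). Compound 4 `Cc1cc(C)c(NC(=O)N(Cc2ccc(-n3cncn3)cc2)C2CCCCCC2)c(C)c1` carries the change (1H-1,2,4-triazol-1-yl in place of 1H-pyrazol-4-yl on an aromatic carbon). Among the measured compounds shown here, no measured step shows this swap, and the two steps into compound 3 set only a floor, so compound 4 is expected to stay near that limit, with the step that the limit leaves unreadable from compound 3 to compound 4 estimated as small. Compound 4 is therefore estimated at 1.5 mg/kg, between 0.6 mg/kg and 4 mg/kg.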

Compound 4, dose for half-maximal effect: > 1 mg/kg
Compound 4 ended at the assay's limit; the forecaster's own chance of this, stated with the estimate: 60%; the middle value is on the limit's open side.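

Removing the hydrogen-bond donor of the 1H-pyrazol-4-yl ring brings no readable value back: compound 4, with its 1H-1,2,4-triazol-1-yl ring, also stands at a limit of this assay. The comparisons give an at least 1.7-fold higher number from compound 2 to compound 4 (0.23 log units; that floor lies within the scatter) and an at least 1.9-fold higher number from compound 1 to compound 4 (0.29 log units; that floor lies within the scatter) and neither floor clearly sets compound 4 apart from compound 1 or compound 2. The limit now holds a second compound with this change of ring: the limit of > 1 mg/kg in this assay, at which 2 of the 4 values shown sit.

On these data alone, the step between compound 3 and compound 4 cannot be read, so any difference between them stays open. Also open, as far as these compounds go, is how an amine or a carboxylic acid on this aromatic carbon would read.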